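This account rests on a few compounds, and the source may have more. Where it says the series, first, only, none or still open, it means among the compounds named here.

Values so far in a functional assay on DU-145 cells (Homo sapiens) for inhibition; on this read-out higher numbers stand for weaker inhibition and lower numbers for stronger inhibition:

- compound 1 `Oc1cccc(-c2cc(-c3ccccc3C(F)(F)F)cc(-c3ccccc3O)n2)c1`: 7250 nM
- compound 2 `Oc1cccc(-c2cc(-c3cccc(C(F)(F)F)c3)cc(-c3ccccc3O)n2)c1`: 13000 nM
- compound 3 `Oc1ccc(-c2cc(-c3ccccc3C(F)(F)F)cc(-c3ccc(O)cc3)n2)cc1`: a limit of the assay, > 50000 nM

Compound 1 and compound 2 share a core and differ in one place: 3-(trifluoromethyl)phenyl in place of 2-(trifluoromethyl)phenyl on an aromatic carbon. That change gives a 1.8-fold higher number from compound 1 to compound 2 (0.25 log units; within the scatter), so the two values cannot be told apart. For compound 3 only a limit is known, (the limit of > 50000 nM in this assay, at which 1 of the 3 values shown sits). How the core of compound 3 differs from the core of compound 1 is not broken down here.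

Compound 4 `Oc1ccc(-c2cc(-c3cccc(C(F)(F)F)c3)cc(-c3ccc(O)cc3)n2)cc1` is not yet measured in this assay. It stands to compound 3 as compound 2 stands to compound 1: 3-(trifluoromethyl)phenyl in place of 2-(trifluoromethyl)phenyl on an aromatic carbon. The surroundings differ, though: in compound 1 the place is meta to a 2-hydroxyphenyl group and meta to a 3-hydroxyphenyl group, whereas in compound 3 it is meta to two 4-hydroxyphenyl groups, so this is the same kind of change, not the same change.

Among the compounds with values here, the only measured instance of this change, a 1.8-fold higher number from compound 1 to compound 2 (0.25 log units; within the scatter), was within the scatter, so for compound 4 the expected step is a step that the limit leaves unreadable from compound 3 to compound 4, small and resting on that single pair. Since compound 3 already sits at the limit of the assay, compound 4 is estimated at 80000 nM, most likely again reported only as a limit, with a range of 40000 nM to 200000 nM.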

Compound 4, half-maximal inhibitory concentration: > 50000 nM
Compound 4 ended at the assay's limit (the forecaster's own chance of this, stated with the estimate: 85%); the middle value lies beyond the limit too.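

Compound 3 and compound 4 both stand at the limit of this assay, so no step can be read between them: the limit of > 50000 nM in this assay, at which 2 of the 4 values shown sit.

The compounds shown leave open whether 3-(trifluoromethyl)phenyl in place of 2-(trifluoromethyl)phenyl changes the read-out at all on the core of compound 3, as neither compound there gives a number.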